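Methyl for methoxy on the aryl ring of compound 2

A few compounds are considered here, and "the series" means these few. Any claim that something is new, unique, unknown or untested is made for them only; others in the source may bear on it.

Compound 1 `Cc1ccccc1-c1cncc(OC[C@@H]2CCCN2C)c1`: 1.1 nM
Compound 2 `COc1ccc(-c2cncc(OC[C@@H]3CCCN3C)c2)cc1`: 0.32 nM

Of the compounds shown here, two sharing one core have been measured in an assay on membranes from brain for binding affinity to Neuronal acetylcholine receptor; alpha4/beta2 (Rattus norvegicus); on this read-out higher numbers stand for weaker inhibition and lower numbers for stronger inhibition. Compound 2 gives 0.32 nM, the lower of the two numbers. Compound 1 gives 1.1 nM, a higher number, and the gap between the two lies beyond the usual scatter of the assay, so compound 2 stands as the more tightly binding of the pair.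

The next compound, compound 3 `Cc1ccc(-c2cncc(OC[C@@H]3CCCN3C)c2)cc1`, has not yet been measured. It differs from compound 2 in one place: methyl in place of methoxy on an aromatic carbon. Among the measured compounds shown here, no measured pair in this set shows this particular exchange, so the size of the step cannot be read off from a precedent.

Given that compound 2 gives 0.32 nM, the expected step from compound 2 to compound 3 is a 1.6-fold higher number from compound 2 to compound 3 (0.19 log units; within the scatter), a modest move toward a higher number that may well fall inside the scatter. Compound 3 is therefore estimated at 0.5 nM, with a likely range from 0.15 nM to 1.6 nM in this assay.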

Compound 3, inhibition constant: 0.13 nM
Compound 3: middle estimate off by 3.8-fold (0.59 log units), on the high side; measured number below the stated range.
By their numbers in this assay, from the lowest: compound 3; then compound 2; then compound 1.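

In this assay, methyl in place of methoxy on the aromatic carbon para to a large group gives a 2.5-fold lower number from compound 2 to compound 3 (0.39 log units; beyond the scatter) and so improves binding, which shows that the oxygen of methoxy and its hydrogen-bond acceptor are not needed for a low number at this position. Among the compounds shown here, compound 3 also allows the first comparison of where the methyl group sits on the aryl ring: 4-methylphenyl in place of 2-methylphenyl gives an 8.5-fold lower number from compound 1 to compound 3 (0.93 log units; beyond the scatter) and makes compound 3 the most tightly binding of the three compounds, with both of its steps beyond the usual scatter. Nothing available here explains why either exchange lowers the number.

As far as these compounds go, whether ethyl, a longer chain, chlorine, a hydroxyl or an amine on the same aromatic carbon would keep or lower the number remains open, so the two groups seen at this position do not yet define a trend. From the compounds shown here alone, it is also open whether 2-methoxyphenyl and the aryl group of compound 2 would differ in the same direction as the two methyl-bearing aryl groups.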